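Removing the amine methyl: compound 3 to compound 4

The source may hold more compounds than are shown below. What is called first, only, known or untested is meant among the compounds shown, and "the series" means these compounds.

Inhibition constants in an assay on isolated protein for displacement of a labelled ligand from D(1B) dopamine receptor (Homo sapiens); a higher number here means a weaker inhibitor, a lower number a stronger inhibitor:
compound 1 `C=CCN1CCc2cc(O)c(O)cc2C(c2ccccc2Br)C1`: 442 nM
compound 2 `C=CCN1CCc2cc(OC)c(O)cc2C(c2ccccc2Cl)C1`: 264 nM
compound 3 `CN1CCc2cc(O)c(O)cc2C(c2ccccc2Br)C1`: 223 nM

Compound 3 has the smallest of the three numbers, but none of the gaps is meaningful: the step from compound 1 to compound 3 in this assay is a 2.0-fold lower number from compound 1 to compound 3 (0.30 log units; within the scatter), and compound 2 gives 264 nM while compound 3 gives 223 nM, a gap within the scatter. Going by the values given here, no step is defined between compound 2 and compound 3, since they differ at two places.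

Compound 4 `Oc1cc2c(cc1O)C(c1ccccc1Br)CNCC2` is not yet measured. It differs from compound 3 by hydrogen in place of methyl on an amine nitrogen in a ring. Among the compounds with values here, the one measured step that touches the same nitrogen is the one from compound 1 to compound 3, a 2.0-fold lower number from compound 1 to compound 3 (0.30 log units; within the scatter), where the substituent on that nitrogen was shortened; it stayed within the scatter. Shortening further, from methyl to hydrogen, is a change of the same kind, and nothing in these three compounds points to a larger effect. The expectation is therefore a step of a 1.2-fold higher number from compound 3 to compound 4 (0.07 log units; within the scatter), with no clear direction beyond the scatter, so that compound 4 is estimated at 260 nM in this assay, within a range of 100 nM to 700 nM.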

Compound 4, inhibition constant: 67 nM
Estimate against measurement, compound 4: 3.9-fold (0.59 log units) above; the measured number lies below the stated range.
By their numbers in this assay, from the lowest: compound 4; then compounds 3, 2 and 1 (each within the scatter of the next).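

In this assay, the amine nitrogen in the ring now appears sensitive to its substituent: a 3.3-fold lower number from compound 3 to compound 4 (0.52 log units; beyond the scatter) lies beyond the scatter, whereas a 2.0-fold lower number from compound 1 to compound 3 (0.30 log units; within the scatter) stayed within it. The longer comparison at the same place, a 6.6-fold lower number from compound 1 to compound 4 (0.82 log units; beyond the scatter), is also beyond the scatter, so among compound 1, compound 3 and compound 4 the difference appears only when the nitrogen carries hydrogen, while allyl and methyl cannot be told apart. The data offer nothing that explains this difference.

From the compounds shown here alone, only the series carrying the 2-bromophenyl group and two hydroxyl groups shows this step, so it remains open whether replacing the nitrogen substituent with hydrogen has a similar effect on the core of compound 2, with its 2-chlorophenyl and methoxy groups. Going by these compounds, it is also open whether an ethyl or a benzyl group on the same nitrogen would stay with methyl and allyl, and so whether hydrogen is a special case or one end of a wider trend.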